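A Second Hydroxy Group on a Core Already at the Limit

The compounds below may be only part of what the source reports. "The series", "measured", "known", "first", "only" and "open" are said of these compounds alone.

The work concerns antiproliferative activity, measured in a functional assay on NCI-H1299 cells (Homo sapiens) for antiproliferative activity, read by fluorescence and resazurin assay, with a stated time of 48 h; on this read-out higher numbers stand for weaker inhibition and lower numbers for stronger inhibition. Compound 1 `COc1ccc(-c2cn(Cc3ccc(O)cc3)cc2-c2ccc(OC)cc2)cc1` gives 20500 nM in this assay. Compound 3 `COc1ccc(-c2cn(Cc3ccc(O)c(O)c3)cc2-c2ccc(OC)cc2)cc1` differs from compound 1 by one change, (hydroxy in place of hydrogen on an aromatic carbon), and in this assay compound 3 gives 19100 nM. The step is a 1.1-fold lower number from compound 1 to compound 3 (0.03 log units; within the scatter), so the added hydroxy group leaves the activity where it was.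

Compound 2 `COc1cc(-c2cn(Cc3ccc(O)cc3)cc2-c2cc(OC)c(OC)c(OC)c2)cc(OC)c1OC` is built on the second core. The difference between the two cores is not broken down here. In this assay compound 2 gives > 100000 nM, which is a limit of the assay and not a number. Compound 2 therefore stands at the limit of > 100000 nM in this assay, at which 1 of the 3 values shown sits.

Compound 4 `COc1cc(-c2cn(Cc3ccc(O)c(O)c3)cc2-c2cc(OC)c(OC)c(OC)c2)cc(OC)c1OC` has not yet been measured. It stands to compound 2 as compound 3 stands to compound 1, through (hydroxy in place of hydrogen on an aromatic carbon), the same change at the same place on the same kind of ring.

The step that the limit leaves unreadable from compound 2 to compound 4 is expected, because the matching step a 1.1-fold lower number from compound 1 to compound 3 (0.03 log units; within the scatter) stayed within the scatter. Compound 4 is therefore expected to remain out of reach in this assay, with an estimated value of about 150000 nM and an expected range from 60000 nM to 400000 nM, most probably reported again only as a limit.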

Compound 4, half-maximal inhibitory concentration: 29200 nM
The estimate for compound 4 lay 5.1-fold (0.71 log units) above the measured number, outside the stated range (below it).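

In this assay, the change from 4-hydroxybenzyl to 3,4-dihydroxybenzyl on the core of compound 2 gives an at least 3.4-fold lower number from compound 2 to compound 4 (0.53 log units; beyond the scatter), whereas the same change left the number on the core of compound 1 within the scatter. The change therefore does not carry over from one core to the other with the same size, and the comparison of the two steps shows this: the same change on two cores in this assay, a 1.1-fold lower number (0.03 log units; within the scatter) from compound 1 to compound 3 and an at least 3.4-fold lower number (0.53 log units; beyond the scatter) from compound 2 to compound 4, at least 3.1-fold (0.50 log units) apart, beyond the scatter of two such steps
Compound 2 is known only through a limit of the assay, > 100000 nM, so the true size of its step remains unknown, and a comparison of two cores neither explains the difference nor gives a rule for any further core in this series.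

The compounds shown leave open whether a different group, such as an amine or a carboxylic acid, placed where the added hydroxy group sits would give a step like the one on the core of compound 2, or whether only hydroxy does so. They also leave open whether a core with fewer methoxy groups than that of compound 2, yet more than that of compound 1, would show a step of intermediate size.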